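From Benzoyl to 4-Methylbenzyl: Tolerance in HEL Cells

The source may hold more compounds than are shown below. What is called first, only, known or untested is meant among the compounds shown, and "the series" means these compounds.

Of the compounds shown here, two that share one core have been tested in an ADME assay on HEL cells (Homo sapiens) for cytotoxicity, with a stated time of 3 days; a higher number here means that more compound is tolerated, a lower number that less compound is tolerated. Compound 1, `CCC1(Cc2ccccc2)OS(=O)(=O)C=C1OCCCc1ccccc1`, gives in this assay >= 20000 nM, which is a limit of the assay rather than a number. Compound 2, `CCC1(Cc2ccccc2)OS(=O)(=O)C=C1OC(=O)c1ccccc1`, gives in this assay > 400000 nM, again a limit of the assay and not a measured number. Within the data shown here, compound 2 therefore sits at the limit of > 400000 nM in this assay, at which 1 of the 2 values shown sits, and compound 1 sits at the limit of >= 20000 nM in this assay, at which 1 of the 2 values shown sits; since both readings are limits, no measured step between them can be stated, and no step between measured compounds is available at all.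

Compound 3, `CCC1(Cc2ccccc2)OS(=O)(=O)C=C1OCc1ccc(C)cc1`, differs from compound 2 in one place: 4-methylbenzyl in place of benzoyl on an oxygen on an unsaturated carbon. Among the measured compounds shown here, with no measured step of this kind to lean on, the expectation rests only on the two limits, both of which lie at high concentrations. Compound 3 is expected to remain well tolerated, and the step of an at least 6.6-fold lower number from compound 2 to compound 3 (0.82 log units; beyond the scatter) is expected to be a moderate move toward lower tolerance, though the starting point is itself only a limit. Compound 3 is estimated at 60000 nM, with a range from 12000 nM to 400000 nM.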

Compound 3, minimum cytotoxic concentration: >= 16000 nM
Compound 3 was reported as a limit; the forecaster's own chance of this, stated with the estimate: 50%; the middle value lies beyond the limit too.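

Compound 1, compound 2 and compound 3 are all reported only as limits in this assay, so the steps from compound 2 to compound 3 and from compound 1 to compound 3 cannot be read. The compounds shown leave open how much of each compound the cells actually tolerate, and whether 4-methylbenzyl in place of benzoyl changes that tolerance at all.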